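The source may report more compounds than this note shows. Statements on the series, on what has been measured and on what is new or still open speak of the compounds shown alone.

Measured in a functional assay on BGC-823 cells (Homo sapiens) for inhibition, read by MTT assay, with a stated time of 72 h; on this read-out higher numbers stand for weaker inhibition and lower numbers for stronger inhibition:

Compound 1 `Cc1cc(N2CC[C@@H](C)[C@@H](N(C)c3ncnc4[nH]ccc34)C2)n2ncnc2n1` gives 67400 nM
Compound 2 `C[C@@H]1CCN(c2cc(-c3ccccc3)nc3ncnn23)C[C@@H]1N(C)c1ncnc2[nH]ccc12` gives > 100000 nM (a limit of the assay, not a number)
Compound 3 `C=CCSc1nc2nc(C)cc(N3CC[C@@H](C)[C@@H](N(C)c4ncnc5[nH]ccc45)C3)n2n1` gives 40900 nM

Compound 2 has no number of its own and stands at the limit of > 100000 nM in this assay, at which 1 of the 3 values shown sits (a limit only).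

Compound 4 `CCc1cc(N2CC[C@@H](C)[C@@H](N(C)c3ncnc4[nH]ccc34)C2)n2ncnc2n1` differs from compound 2 by one change (ethyl in place of phenyl on an aromatic carbon), and its ethyl sits on the aromatic carbon that carries methyl in compound 1. For the measured compounds named here, two measured steps bear on this. The nearer one, phenyl in place of methyl on that carbon, gave an at least 1.4-fold higher number from compound 1 to compound 2 (0.17 log units; that floor lies within the scatter), and its size is known only as a floor. The other, allylsulfanyl in place of hydrogen on an aromatic carbon, gave a 1.6-fold lower number from compound 1 to compound 3 (0.22 log units; within the scatter), so it offers little guidance here.

Since compound 1 (with 67400 nM) is the closest measured relative, a modest move toward a lower number is expected, with nothing clearly beyond the scatter. The expected step is an at least 1.8-fold lower number from compound 2 to compound 4 (0.25 log units; that floor lies within the scatter) in this assay as estimated here. For compound 4 the estimate is 55000 nM (expected range 25000 nM to 100000 nM).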

Compound 4, half-maximal inhibitory concentration: 82200 nM
Beside the measured number, compound 4's estimate is 1.5-fold (0.17 log units) below it; the range from low to high includes it.
By their numbers in this assay, from the lowest: compounds 3, 1 and 4 (each within the scatter of the next). At a limit, above all of these: compound 2.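

In this assay, going from methyl to ethyl on this aromatic carbon gives a 1.2-fold higher number from compound 1 to compound 4 (0.09 log units; within the scatter), so this first small extension of the group leaves compound 4 indistinguishable from compound 1. Ethyl in place of phenyl can be read only as a floor, an at least 1.2-fold lower number from compound 2 to compound 4 (0.08 log units; that floor lies within the scatter), and that floor rests on a limit rather than a number: the limit of > 100000 nM in this assay, at which 1 of the 4 values shown sits. The true gap between these two groups may therefore be larger, but so far no step at this carbon is shown to lie beyond the scatter.

Going by these compounds, how much phenyl really differs from ethyl here remains unknown. On these data alone, it is also open whether a longer chain such as butyl, or an amine or a carboxylic acid on this carbon, would give a number clearly separate from those of compound 1 and compound 4.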